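This account rests on a few compounds, and the source may have more. Where it says the series, first, only, none or still open, it means among the compounds named here.

Compound 1 `CCCCCCCCC(=O)N1c2ccccc2CCC1C(=O)Nc1ccccc1C(F)(F)F` and compound 2 `CC(=O)N1c2ccccc2CCC1C(=O)Nc1ccccc1C(F)(F)F` share one core and differ only in the chain attached to the carbonyl on the ring nitrogen. In a functional assay on NUGC-3 cells (Homo sapiens) for cytotoxicity, read by sulforhodamine B assay, with a stated time of 72 h (a higher number here means a weaker inhibitor of growth, a lower number a stronger inhibitor of growth), compound 1 gives 6180 nM. For compound 2 this assay reports only a limit, > 80000 nM, so its true value is not known as a number. Going by the values given here, the one measured step, an at least 12-fold higher number from compound 1 to compound 2 (1.11 log units; beyond the scatter), is therefore large, but its size is bounded only on one side because of the limit of > 80000 nM in this assay, at which 1 of the 2 values shown sits.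

Compound 3 `CCC(=O)N1c2ccccc2CCC1C(=O)Nc1ccccc1C(F)(F)F` has not yet been measured in this assay. It differs from compound 2 by methyl in place of hydrogen on a saturated chain carbon bound to a carbonyl carbon. This is a much smaller change than the measured step, which removed a heptyl chain; here a single carbon is added back. The measured step points toward longer chains giving lower numbers, so a modest move in that direction is expected, though probably not enough to leave the weak region, and a second limit is quite possible. The estimate for compound 3 is 70000 nM, within a range of 30000 nM to 160000 nM, a step of an at least 1.1-fold lower number from compound 2 to compound 3 (0.05 log units; that floor lies within the scatter) that is expected, not measured.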

Compound 3, concentration for 50% growth inhibition: > 80000 nM
Compound 3: a limit, no number (the forecaster's own chance of this, stated with the estimate: 55%); middle value at least 1.1-fold (0.05 log units) from the limit.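

Adding methyl to the acetyl group of compound 2 gives the propanoyl group of compound 3, and this small extension does not produce a readable number. In this assay, compound 3 gives > 80000 nM, which is a limit and not a number. Measured against the long chain of compound 1, the shorter chain shows an at least 12-fold higher number from compound 1 to compound 3 (1.11 log units; beyond the scatter), so the large gap seen with the acetyl group also appears with the propanoyl group. The step between compound 2 and compound 3 cannot be read, and the result shows only that this one added carbon leaves the compound at the same limit: the limit of > 80000 nM in this assay, at which 2 of the 3 values shown sit.

The compounds shown leave open how much of the heptyl chain is needed for a readable number, which a propyl, butyl or pentyl chain at this place could help to locate. They also leave open whether a chain longer than heptyl would give a lower number, and whether an amine or a carboxylic acid at the end of the chain would keep the growth inhibition seen with compound 1.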